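The source may hold more compounds than are shown below. What is called first, only, known or untested is meant among the compounds shown, and "the series" means these compounds.

Compound 1 `CCSC(=S)SCC(=O)c1ccc(Cl)c(Cl)c1` is the reference for this note. Within the data shown here, in a functional assay on HeLa cells (Homo sapiens) for antiproliferative activity, read by resazurin assay (a lower number here means a stronger inhibitor, a higher number a weaker inhibitor), compound 1 gives 7940 nM, the second highest of the three numbers measured so far. Compound 2 `CCSC(=S)SCC(=O)c1ccc(Cl)cc1`, which in this assay gives 5010 nM, is the nearest of the three: the step of a 1.6-fold lower number from compound 1 to compound 2 (0.20 log units; within the scatter) is within the scatter, so no order between compound 1 and compound 2 is claimed. Compound 3 `COc1ccc(C(=O)CSC(C)=O)cc1` lies furthest from compound 1; in this assay compound 3 gives 25100 nM, and the gap between these two values is beyond the scatter.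

Compound 4 `CC(C)SC(=S)SCC(=O)c1ccc(Cl)c(Cl)c1` has not been measured. It differs from compound 1 by methyl in place of hydrogen on a saturated chain carbon bound to a saturated chain carbon and a sulfur, which, cut one bond further out, reads ethyl to isopropyl, or ethylsulfanyl to isopropylsulfanyl. Among the measured compounds shown here, none of the measured steps touches this part of the molecule: the only one-place step, from compound 1 to compound 2, alters the aromatic ring and is within the scatter, and the pair of compound 1 and compound 3 differs in several places at once. For the measured compounds named here, there is therefore no measured precedent for the change, and no step beyond the scatter is expected for this assay.

Compound 4 is accordingly expected to give about 8000 nM, in the range 3500 nM to 18000 nM; this estimate means a step of a 1.0-fold higher number from compound 1 to compound 4 (0.00 log units; within the scatter).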

Compound 4, half-maximal inhibitory concentration: 25100 nM
For compound 4 the middle estimate is 3.1-fold (0.50 log units) below the measured one, and the stated range ends below it.
By their numbers in this assay, from the lowest: compounds 2 and 1 (each within the scatter of the next); then compounds 3 and 4 (each within the scatter of the next).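

In this assay, among these compounds, the ethylsulfanyl end of the core of compound 1 is the first place where a single one-place change gives a step beyond the scatter: ethylsulfanyl to isopropylsulfanyl gives a 3.2-fold higher number from compound 1 to compound 4 (0.50 log units; beyond the scatter), toward a weaker inhibitor. Among the compounds shown here, the only earlier one-place step, on the aromatic ring, is a 1.6-fold lower number from compound 1 to compound 2 (0.20 log units; within the scatter) and stays within the scatter, so this saturated chain carbon bound to a saturated chain carbon and a sulfur responds to one added methyl, while that ring change gave no readable difference. Nothing shown here explains why this added methyl carries that step.

A single substitution at this carbon cannot tell whether the step follows the branch itself or the extra carbon, and a straight propyl chain or a methyl in place of the ethyl would separate the two readings. Also open, from the compounds shown here alone, are whether a cyclopropyl group or a chain ending in an amine or a carboxylic acid is tolerated here, and whether the same ethyl to isopropyl change gives a similar step on the core of compound 2.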